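The source may report more compounds than this note shows. Statements on the series, on what has been measured and on what is new or still open speak of the compounds shown alone.

Working notes on the series. Compound 1 `CCN(CC)c1nc(-n2nc(-c3ccccn3)nc2N)c2cc(OC)c(OC)cc2n1` and compound 2 `COc1cc2ncnc(-n3nc(-c4ccccn4)nc3N)c2cc1OCCCN1CC(C)OC(C)C1` share one core and have both been run in an assay on MCF7 cells for inhibition of Serine-protein kinase ATM (Homo sapiens), read by immunofluorescence, with a stated time of 1 h; on this read-out lower numbers stand for stronger inhibition and higher numbers for weaker inhibition. For compound 1 the read-out is a limit of the assay, > 40000 nM, and not a number. That entry for compound 1 is the limit of > 40000 nM in this assay, at which 1 of the 2 values shown sits. Among the compounds with values here, compound 2 gives 1600 nM in this assay, which is the only number in the set so far. Within the data shown here, no pair of measured compounds differing in a single place exists here, so no measured step is available to lean on.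

Compound 3 `COc1cc2ncnc(-n3nc(-c4ccccn4)nc3N)c2cc1OCCCNC(=O)OCC(F)(F)F` awaits measurement in this assay. Against compound 2 the change is ((2,2,2-trifluoroethoxy)carbonyl)amino in place of 2,6-dimethylmorpholin-4-yl on a saturated chain carbon, three bonds along the chain from an oxygen on an aromatic ring The substitution sits on a saturated chain carbon, three bonds along the chain from an oxygen on an aromatic ring, the rest of the molecule being unchanged.

Among the measured compounds shown here, with no measured step to anchor it, the expected step of a 2.0-fold higher number from compound 2 to compound 3 (0.30 log units; within the scatter) is taken as a modest move toward weaker inhibition in this assay, possibly not beyond the usual scatter. Compound 3 is therefore estimated at 3200 nM, with a likely range from 900 nM to 12000 nM.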

Compound 3, half-maximal inhibitory concentration: 1200 nM
For compound 3 the middle estimate is 2.7-fold (0.43 log units) above the measured one; measured number inside the range.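

In this assay, within the data shown here, ((2,2,2-trifluoroethoxy)carbonyl)amino in place of 2,6-dimethylmorpholin-4-yl on a saturated chain carbon, three bonds along the chain from an oxygen on an aromatic ring, gives a 1.3-fold lower number from compound 2 to compound 3 (0.12 log units; within the scatter), the first measured step, and the two groups cannot be told apart on this read-out. This position therefore accepts an open group with no ring and with a hydrogen-bond donor in place of a six-membered non-aromatic ring with no donor, and the two compounds still read alike. Nothing measured in the set bears on why the two compounds read alike.

From the compounds shown here alone, whether a primary amine or a carboxylic acid at this chain carbon, or a longer chain carrying either group, would read the same in this assay remains open. Among these compounds, for compound 1 the entry is a limit of the assay, > 40000 nM, and that compound differs from the others in more than one place, so it gives no step for this position.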